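The source may report more compounds than this note shows. Statements on the series, on what has been measured and on what is new or still open speak of the compounds shown alone.

Measured compounds in an assay on membranes from CHO cells for displacement of a labelled ligand from adenosine receptor A1 (Homo sapiens), read by scintillation counting, with a stated time of 60 min, tested at 1 uM; a lower number here means less inhibition, a higher number more inhibition at the concentration tested (going by the name of the read-out):
compound 1, `CCNC(=O)C1=C(C)NC(=O)NC1c1ccco1`, 2%
compound 2, `CCNC(=O)C1=C(C)NC(=O)NC1c1ccoc1`, 1%
compound 3, `CCNC(=O)C1=C(C)NC(=O)NC1c1cccs1`, 1%

Compound 1 carries the number that is nominally the highest of the three, yet the steps of a number 1 percentage points lower from compound 1 to compound 2 (within the scatter) and a number 1 percentage points lower from compound 1 to compound 3 (within the scatter) both lie within the scatter, so the three compounds are indistinguishable and all show barely any inhibition. Compound 4, `CC1=C(C(=O)OC2CCCCC2)C(c2ccco2)NC(=O)N1`, changes something else: cyclohexyloxy in place of ethylamino on a carbonyl carbon. Going by the values given here, none of the measured steps touches this carbonyl group; each of them swaps the aromatic ring on the saturated ring carbon, and no change at the digits printed from compound 2 to compound 3 (within the scatter) adds nothing on this point. Among the compounds with values here, with no step bearing on the change and every measured number near zero, compound 4 is expected to stay near zero, a step of a number 3 percentage points higher from compound 1 to compound 4 (within the scatter). The estimate for compound 4 is 5%, ranging from 0% to 25%.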

Compound 4, a percentage reported as inhibition, at one concentration (the size of the read-out at that concentration, not a potency): 1%
Estimate against measurement, compound 4: 4 percentage points above; the range from low to high includes it.
By their numbers in this assay, from the lowest: compounds 2, 3, 4 and 1 (each within the scatter of the next).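

Unlike the earlier steps, which swap the aromatic ring, this one changes the group on the carbonyl carbon, and in this assay it gives a number 1 percentage points lower from compound 1 to compound 4 (within the scatter). Neither the entering six-membered ring nor the loss of a hydrogen-bond donor lifts the number clear of the scatter, so this change leaves inhibition barely detectable. Nothing available explains this result.

Going by these compounds, with every number near zero, it remains open whether this position can influence inhibition at all. A benzylamino group or a free carboxylic acid on the carbonyl carbon might give a clearer answer.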